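The compounds below may be only part of what the source reports. "The series", "measured", "known", "first", "only" and "open" are said of these compounds alone.

Measured compounds:
compound 1 `CCCc1cc(N)c2cc(NC(=O)/C=C/c3ccc(CC)cc3)ccc2n1`, 1.4 nM
compound 2 `CCCCc1ccc(/C=C/C(=O)Nc2ccc3nc(CCC)cc(N)c3c2)cc1`, 45 nM
compound 3 `CCCc1cc(NC)c2cc(NC(=O)/C=C/c3ccc(C(F)(F)F)cc3)ccc2n1`, 1.5 nM

In an assay on isolated protein for displacement of a labelled ligand from melanin-concentrating hormone receptor 1 (Homo sapiens) (on this read-out higher numbers stand for weaker inhibition and lower numbers for stronger inhibition), compound 1 gives 1.4 nM, the lowest of the three numbers shown; compound 3 sits within the scatter of it, while compound 2 lies well beyond. Among the compounds with values here, the one step between measured compounds that differ in a single place is a 32-fold higher number from compound 1 to compound 2 (1.51 log units; beyond the scatter), which concerns a longer chain on the same aromatic ring, not a change of the ring's substituent pattern. Compound 4 `CCCc1cc(N)c2cc(NC(=O)/C=C/c3cccc(Cl)c3)ccc2n1` differs from compound 1 by 3-chlorophenyl in place of 4-ethylphenyl on a double-bonded chain carbon bound to a double-bonded chain carbon. Within the data shown here, no measured step covers this change. Compound 3, which carries a different group on that ring and also a methylamino group on the core, gives 1.5 nM, showing that a second substituent on this ring can coexist with a low number, but it does not speak to the change made here. The step to compound 2 shows the ring substituent can matter a great deal. Compound 4 is therefore expected to give 5 nM, somewhere between 1.2 nM and 25 nM, a step of a 3.6-fold higher number from compound 1 to compound 4 (0.55 log units; beyond the scatter) towards a higher number.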

Compound 4, half-maximal inhibitory concentration: 1100 nM
For compound 4 the middle estimate is 220-fold (2.34 log units) below the measured one; the measured number lies above the stated range.
By their numbers in this assay, from the lowest: compounds 1 and 3 (each within the scatter of the next); then compound 2; then compound 4.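

In this assay, the exchange of 4-ethylphenyl for 3-chlorophenyl on a double-bonded chain carbon bound to a double-bonded chain carbon gives a 790-fold higher number from compound 1 to compound 4 (2.90 log units; beyond the scatter), and this step is larger than a 32-fold higher number from compound 1 to compound 2 (1.51 log units; beyond the scatter). The earlier compounds shown here showed that lengthening the chain on this ring could raise the number, whereas this result shows a far larger rise with a ring group of nearly the same count, 7 heavy atoms against 8, and with no hydrogen-bond donors or acceptors on either side. Nothing at hand explains the size of this step. The compounds shown leave open how much of the step belongs to losing the ethyl group and how much to the chlorine and its place. They also leave open how a plain phenyl or a methoxy-bearing phenyl would read here.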